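The compounds below may be only part of what the source reports. "The series", "measured", "known", "first", "only" and "open" are said of these compounds alone.

Compound 1 `CN1[C@@H]2c3[nH]c4ccccc4c3C[C@H]1[C@H](C#N)N1[C@@H](CNC(=O)c3ccc(Cl)cc3)c3[nH]c4ccccc4c3C[C@@H]21` has the second highest of the three numbers seen so far in a functional assay on HCT-116 cells (Homo sapiens) for cytotoxicity, read by MTT assay, with a stated time of 72 h (a lower number here means a stronger inhibitor, a higher number a weaker inhibitor), giving 630 nM. Compound 2 `CCc1ccc(C(=O)NC[C@H]2c3[nH]c4ccccc4c3C[C@H]3[C@H]4c5[nH]c6ccccc6c5C[C@@H]([C@H](C#N)N23)N4C)cc1` gives 100 nM, and compound 3 `CN1[C@@H]2c3[nH]c4ccccc4c3C[C@H]1[C@H](C#N)N1[C@@H](CNC(=O)c3cccc4c3CCCC4)c3[nH]c4ccccc4c3C[C@@H]21` gives 4210 nM. The steps among them are a 6.3-fold lower number from compound 1 to compound 2 (0.80 log units; beyond the scatter) and a 6.7-fold higher number from compound 1 to compound 3 (0.82 log units; beyond the scatter), so both replacements of the 4-chlorophenyl group moved the number beyond the scatter, in opposite directions. Compound 4 `CN1[C@@H]2c3[nH]c4ccccc4c3C[C@H]1[C@H](C#N)N1[C@@H](CNC(=O)c3cc4ccccc4[nH]3)c3[nH]c4ccccc4c3C[C@@H]21` differs from compound 1 by 1H-indol-2-yl in place of 4-chlorophenyl on a carbonyl carbon. Going by the values given here, of the measured steps, the one from compound 1 to compound 3 also brought in a fused two-ring group on the carbonyl carbon, and there the number rose by a 6.7-fold higher number from compound 1 to compound 3 (0.82 log units; beyond the scatter). A modest rise is therefore expected, a 2.1-fold higher number from compound 1 to compound 4 (0.31 log units; beyond the scatter), and compound 4 is estimated at 1300 nM, with a range from 400 nM to 4200 nM.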

Compound 4, half-maximal inhibitory concentration: 880 nM
Compound 4: the middle estimate sits 1.5-fold (0.17 log units) above what was measured; the range from low to high includes it.
By their numbers in this assay, from the lowest: compound 2; then compounds 1 and 4 (each within the scatter of the next); then compound 3.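

In this assay, swapping 4-chlorophenyl for 1H-indol-2-yl on the carbonyl carbon, which adds a five-membered aromatic ring and a hydrogen-bond donor, gives a 1.4-fold higher number from compound 1 to compound 4 (0.15 log units; within the scatter), so the two groups cannot be told apart here. A fused two-ring group at this position therefore need not carry the penalty seen with 1,2,3,4-tetrahydronaphthalen-5-yl, as shown by a 4.8-fold lower number from compound 3 to compound 4 (0.68 log units; beyond the scatter), although 4-ethylphenyl keeps the lower number, with an 8.8-fold higher number from compound 2 to compound 4 (0.94 log units; beyond the scatter). No measured information is available to explain these differences. From the compounds shown here alone, what an amine or a carboxylic acid in place of the ethyl of compound 2 would do remains open.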